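The source may report more compounds than this note shows. Statements on the series, on what has been measured and on what is new or still open speak of the compounds shown alone.

Values in a functional assay on HepG2 cells (Homo sapiens) for inhibition, read by MTT assay, with a stated time of 120 h; on this read-out lower numbers stand for stronger inhibition and higher numbers for weaker inhibition:
- compound 1 `O=C(/C=C/c1ccc(NC(=O)Nc2ccc(Cl)c(C(F)(F)F)c2)cc1)NC1CCC1`: 7510 nM
- compound 2 `CNC(=O)c1cccc(-c2ccc(NC(=O)Nc3ccc(Cl)c(C(F)(F)F)c3)cc2)c1`: 37100 nM
- compound 3 `O=C(CCc1ccc(NC(=O)Nc2ccc(Cl)c(C(F)(F)F)c2)cc1)NC1CCC1`: > 50000 nM (a limit)

Compound 3 has no number, only a limit: > 50000 nM (the limit of > 50000 nM in this assay, at which 1 of the 3 values shown sits). Compound 4 `CNC(=O)CCc1ccc(NC(=O)Nc2ccc(Cl)c(C(F)(F)F)c2)cc1` differs from compound 3 by methyl in place of cyclobutyl on an amide-type nitrogen. Within the data shown here, no measured step isolates this change. The nearest evidence is indirect: an at least 6.6-fold higher number from compound 1 to compound 3 (0.82 log units; beyond the scatter) and an at least 1.3-fold higher number from compound 2 to compound 3 (0.12 log units; that floor lies within the scatter). Compound 2 also carries methylcarbamoyl and gives 37100 nM. Compound 4 is therefore expected to stay weak in this assay, close to the limit, and no step beyond the scatter is expected, the estimate being an at least 1.1-fold lower number from compound 3 to compound 4 (0.04 log units; that floor lies within the scatter). For compound 4 the estimated value is 45000 nM, with an expected range of 20000 nM to 80000 nM.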

Compound 4, half-maximal inhibitory concentration: 21000 nM
Beside the measured number, compound 4's estimate is 2.1-fold (0.33 log units) above it; the measured number falls inside the stated range.
By their numbers in this assay, from the lowest: compound 1; then compounds 4 and 2 (each within the scatter of the next). At a limit, above all of these: compound 3.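

In this assay, methyl in place of cyclobutyl on an amide-type nitrogen brings the saturated chain off the limit, with an at least 2.3-fold lower number from compound 3 to compound 4 (0.37 log units; beyond the scatter). Compound 3 itself holds only a limit: the limit of > 50000 nM in this assay, at which 1 of the 4 values shown sits. 2-(methylcarbamoyl)ethyl and 3-(methylcarbamoyl)phenyl on the aromatic carbon are not separated, with a 1.8-fold lower number from compound 2 to compound 4 (0.25 log units; within the scatter), while 2-(cyclobutylcarbamoyl)ethenyl stays ahead of 2-(methylcarbamoyl)ethyl, with a 2.8-fold higher number from compound 1 to compound 4 (0.45 log units; beyond the scatter).

Still open, going by these compounds, is how ethyl or cyclopropyl on that amide-type nitrogen would read. Also open, on these data alone, is whether methyl in place of cyclobutyl gives a similar step on the ethenyl chain of compound 1.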